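Chloro for bromo on the fused ring: compound 4 expected

The compounds below may be only part of what the source reports. "The series", "measured", "known", "first", "only" and "open" are said of these compounds alone.

Measured compounds:
compound 1 `COC(=O)C1=C(N)Oc2ccc(Br)cc2C1CC(=O)c1ccc(Br)cc1`: 72.5%
compound 2 `COC(=O)C1=C(N)Oc2ccc(Br)cc2C1CC(=O)c1ccccc1`: 107%
compound 3 `COC(=O)C1=C(N)Oc2ccc(Br)cc2C1CC(=O)c1ccc(Cl)cc1`: 67.6%

The three compounds were tested in a functional assay on MCF7 cells (Homo sapiens) for antiproliferative activity, read by sulforhodamine B assay, with a stated time of 72 h, tested at 10 uM; a lower number here means a stronger effect, a higher number a weaker effect of the compound at the concentration tested. On these numbers compound 2 stands highest; its nearest neighbour is compound 1, and the gap is a number 34.5 percentage points higher from compound 1 to compound 2 (beyond the scatter), beyond the scatter. Compound 3 lies furthest from it, with a number 39.4 percentage points lower from compound 2 to compound 3 (beyond the scatter). Between compound 1 and compound 3 the exchange of bromo for chloro on an aromatic carbon gives a number 4.9 percentage points lower from compound 1 to compound 3 (within the scatter), within the scatter.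

Compound 4 `COC(=O)C1=C(N)Oc2ccc(Cl)cc2C1CC(=O)c1ccccc1` has not yet been measured. It differs from compound 2 in one place: chloro in place of bromo on an aromatic carbon

Within the data shown here, the only measured step that bears directly on this exchange is the one from compound 1 to compound 3, the same swap of bromo for chloro on an aromatic carbon elsewhere in the molecule, which was a number 4.9 percentage points lower from compound 1 to compound 3 (within the scatter). The large steps from compound 1 to compound 2 and from compound 2 to compound 3 concern a different change and do not speak to it. The account therefore expects no step beyond the scatter in this assay for compound 4; the estimated step is a number 6 percentage points lower from compound 2 to compound 4 (within the scatter). For compound 4 the expected value is 101%, with a range from 84% to 116%.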

Compound 4, a percentage reported as activity, at one concentration (the size of the read-out at that concentration, not a potency): 87.2%
The estimate for compound 4 lay 13.8 percentage points above the measured number; low and high end bracket the measured number.
By their numbers in this assay, from the lowest: compounds 3 and 1 (each within the scatter of the next); then compound 4; then compound 2.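

In this assay, chloro in place of bromo at this position, on an aromatic carbon meta to a fused ring and para to a fused ring, is not a silent exchange: the result is a number 19.8 percentage points lower from compound 2 to compound 4 (beyond the scatter). Among these compounds, all the earlier compounds carried bromo here, so they could show only what the halogen exchange did elsewhere in the molecule, and that step stayed within the scatter. The same exchange thus does not give the same step in the two settings, and its size in this assay depends on where in the molecule it is made, at least for these two pairs: the same change on two cores in this assay, a number 4.9 percentage points lower (within the scatter) from compound 1 to compound 3 and a number 19.8 percentage points lower (beyond the scatter) from compound 2 to compound 4, 14.9 percentage points apart, beyond the scatter of two such steps.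

The compounds shown leave open how a fluoro, a methoxy or an amine at this position would read, and whether the step seen here would hold in a compound that also carries chloro or bromo at the other halogen site. They also rest on a read-out at a single concentration, so they show the size of the effect at that concentration and say nothing about how potency changes with the exchange.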